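The source may hold more compounds than are shown below. What is called first, only, known or untested is meant among the compounds shown, and "the series" means these compounds.

Compounds measured so far:
compound 1, `CC[C@@H](CCn1cncn1)c1ccc(F)cc1`: 91.6 ug/mL
compound 2, `CC[C@@H](CCn1cncn1)c1ccc(Cl)cc1`: 55.3 ug/mL
compound 3, `CC[C@H](CCn1cncn1)c1ccc(OC)cc1`: 118 ug/mL

All three share one core and were tested in an ADME assay on RD cells (Homo sapiens) for cytotoxicity, read by MTT assay, with a stated time of 3 days; a lower number here means that less compound is tolerated, a higher number that more compound is tolerated. Among them, compound 3 stands with the largest of the three numbers; against compound 1 the gap is within the usual scatter, whereas against compound 2 it is beyond it. Among the measured compounds shown here, the one single-point step that is measured, a 1.7-fold lower number from compound 1 to compound 2 (0.22 log units; within the scatter), concerns a change of the halogen on the aromatic carbon and is within the scatter.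

Compound 4, `CC[C@@H](CCn1cncn1)c1ccc(OC)cc1`, has not yet been tested in this assay. Its relation to compound 3 is the two compounds have the same atoms and bonds and differ only in configuration as drawn: 1 of 1 stereo elements differ; a stereocentre at a saturated chain carbon is drawn R in compound 3 and S in compound 4. For the measured compounds named here, no measured pair among the three compounds differs only in configuration, so no step speaks directly to this change. Going by the values given here, the only measured step, a 1.7-fold lower number from compound 1 to compound 2 (0.22 log units; within the scatter), is small and concerns a substituent rather than a stereocentre. Because compound 3 gives 118 ug/mL and nothing in the data points toward a shift in either direction, the expected step is a 1.1-fold lower number from compound 3 to compound 4 (0.03 log units; within the scatter), that is, none beyond the scatter. Compound 4 is therefore estimated at 110 ug/mL, within a range from 60 ug/mL to 200 ug/mL.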

Compound 4, half-maximal cytotoxic concentration: 115 ug/mL
The estimate for compound 4 lay 1.0-fold (0.02 log units) below the measured number; the range from low to high includes it.
By their numbers in this assay, from the lowest: compounds 2, 1, 4 and 3 (each within the scatter of the next, the first and the last beyond it).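

In this assay, among the compounds shown here, the first pair to test the stereocentre at the saturated chain carbon shows no readable effect of configuration with methoxy on the aromatic carbon, with a 1.0-fold lower number from compound 3 to compound 4 (0.01 log units; within the scatter). This reading concerns configuration alone, because only one thing separates the two compounds: the fact that compounds 3 and 4 differ only in the configuration as drawn. The substituent on the aromatic carbon can now also be read against methoxy with the configuration drawn alike: a 2.1-fold higher number from compound 2 to compound 4 (0.32 log units; beyond the scatter) is a modest step beyond the scatter for methoxy in place of chloro, whereas a 1.3-fold higher number from compound 1 to compound 4 (0.10 log units; within the scatter) stays within the scatter for methoxy in place of fluoro, so only the chloro compound stands apart from compound 4, and even that compound is not separated from the fluoro compound 1.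

The compounds shown leave open whether the configuration at this carbon is equally without a readable effect when fluoro or chloro sits on the aromatic carbon, as the methoxy pair is the only pair here that differs in configuration. Also open, as far as these compounds go, is how the number in this assay would respond to an amine or a carboxylic acid in place of the methoxy on the aromatic carbon, or to a longer chain.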